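The compounds below may be only part of what the source reports. "The series", "measured", "known", "first", "only" and "open" are said of these compounds alone.

Measured compounds in an assay on HEK293 cells for positive allosteric modulation of metabotropic glutamate receptor 3 (Rattus norvegicus), read by thallium flux, with a stated time of 2.5 min; a lower number here means a smaller maximal response, a higher number a larger maximal response:

compound 1, `COc1cc(C(=O)O)ccc1OCCCCOc1ccc(C(=O)CC(C)(C)C)c(O)c1C`: 109%
compound 2, `COc1cc(C(=O)O)ccc1OCCCCOc1ccc(C(=O)CC(C)C)c(O)c1C`: 73.9%
compound 3, `COC(=O)c1ccc(OCCCCOc2ccc(C(=O)CC3CCCC3)c(C)c2C)cc1`: 24.2%

For the measured compounds named here, compound 2 stands second highest of the three numbers in this assay: compound 1 lies a number 35.1 percentage points lower from compound 1 to compound 2 (beyond the scatter), a step that goes beyond the scatter, while the number for compound 3 lies far below that of compound 2; compound 3 differs from compound 2 in several places at once, so no single step can be drawn between them.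

Compound 4, `Cc1c(OCCCCOc2ccc(C(=O)O)cc2Cl)ccc(C(=O)CC(C)C)c1O`, is not yet measured. It differs from compound 2 in one place: chloro in place of methoxy on an aromatic carbon. The change sits on an aromatic carbon of a six-membered aromatic ring of carbon only, ortho to a large group and meta to a carboxy group.

Going by the values given here, the only measured single step, from compound 1 to compound 2, concerns a saturated chain carbon and does not touch the aromatic ring, so no measured step bears directly on this change. Nothing in the numbers therefore points to a step beyond the scatter in this assay in either direction. Compound 4 is expected to give a largest response near that of compound 2, 70%, with a range from 45% to 95%, which would mean a step of a number 3.9 percentage points lower from compound 2 to compound 4 (within the scatter).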

Compound 4, largest response reached (reported as percent of maximum), in percent of the reference or control that the assay uses: 62.9%
For compound 4 the middle estimate is 7.1 percentage points above the measured one; low and high end bracket the measured number.
By their numbers in this assay, from the lowest: compound 3; then compound 4; then compound 2; then compound 1.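

In this assay, the aromatic carbon ortho to a large group and meta to a carboxy group now has a measured single change: chloro in place of methoxy gives a number 11 percentage points lower from compound 2 to compound 4 (beyond the scatter), a modest step. Compound 4 still reaches 62.9%, so on this core the methoxy group is not needed for a sizeable response, although the chloro replacement does not fully match it. Nothing measured here explains why this change lowers the response.

The compounds shown leave open how other groups at this carbon, such as fluoro, a nitrile, an amine or a longer ether chain, would compare with methoxy and chloro. They also leave open whether chloro in place of methoxy would give a similar step on the core of compound 1, which carries the larger branched chain.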